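Amide-side aryl variation on the shared core

The source may report more compounds than this note shows. Statements on the series, on what has been measured and on what is new or still open speak of the compounds shown alone.

Measured so far:
compound 1 `COc1ccc(-n2nc(C(=O)Nc3ccccc3OC)nc2-c2cc(OC)c(OC)c(OC)c2)cc1`: 44%
compound 2 `COc1ccc(-n2nc(C(=O)Nc3ccc(C)cc3)nc2-c2cc(OC)c(OC)c(OC)c2)cc1`: 88%
compound 3 `COc1ccc(-n2nc(C(=O)Nc3ccc(C(F)(F)F)cc3)nc2-c2cc(OC)c(OC)c(OC)c2)cc1`: 96%

All three were run in a functional assay on the whole organism for inhibition, with Rattus norvegicus as the target, read by paw edema, with stated times of 30 min and 3 h, at a dose of 0.28 mmol/kg by the oral route; a lower number here means less inhibition, a higher number more inhibition at the dose given (going by the name of the read-out). Compound 3 holds the highest number of the three, a number 52 percentage points higher from compound 1 to compound 3 (beyond the scatter), while the gap a number 8 percentage points higher from compound 2 to compound 3 (within the scatter) lies within the scatter, so compound 2 and compound 3 cannot be ordered. Compound 4 `COc1ccc(-n2nc(C(=O)Nc3ccc(C(=O)O)cc3)nc2-c2cc(OC)c(OC)c(OC)c2)cc1` differs from compound 3 by carboxy in place of trifluoromethyl on an aromatic carbon. Among the measured compounds shown here, the only step at that same aromatic carbon, a number 8 percentage points higher from compound 2 to compound 3 (within the scatter), was small; the large steps of a number 44 percentage points higher from compound 1 to compound 2 (beyond the scatter) and a number 52 percentage points higher from compound 1 to compound 3 (beyond the scatter) concern the exchange of the whole 2-methoxyphenyl and bear less directly. For the measured compounds named here, no measured compound carries a carboxy, so the expectation is broad. Compound 4 is estimated at 70%, range 40% to 95%. The expected step of a number 26 percentage points lower from compound 3 to compound 4 (beyond the scatter) is a modest decrease, possibly within the scatter.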

Compound 4, a percentage reported as inhibition, in the whole organism at one dose (the size of the read-out at that dose, not a potency): 109%
Estimate against measurement, compound 4: 39 percentage points below; the whole stated range lies below it.
By their numbers in this assay, from the lowest: compound 1; then compounds 2 and 3 (each within the scatter of the next); then compound 4.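

In this assay the aromatic carbon para to a large group accepts carboxy with a gain, not a loss: a number 13 percentage points higher from compound 3 to compound 4 (beyond the scatter) and a number 21 percentage points higher from compound 2 to compound 4 (beyond the scatter). A group with a hydrogen-bond donor and acceptor therefore serves here, where trifluoromethyl has neither, and a number 65 percentage points higher from compound 1 to compound 4 (beyond the scatter) is the largest step in the series. No evidence at hand bears on the reason for this rise.

Going by these compounds, whether a primary amine or a methyl ester on the same aromatic carbon holds this level remains open, as does whether the carboxy step keeps its size at other doses.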